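An aromatic ring in place of ethyl on the amide carbonyl

A few compounds are considered here, and "the series" means these few. Any claim that something is new, unique, unknown or untested is made for them only; others in the source may bear on it.

Among the measured compounds shown here, compound 1 `CCC(=O)N[C@@H](C)c1ccc(NC(=O)[C@H]2C[C@@H]2c2cccnc2)cc1` is the only member of this set with a full number in a physicochemical assay for solubility, at pH 6.8; on this read-out lower numbers stand for lower solubility and higher numbers for higher solubility: compound 1 gives 54000 nM. Compound 2 `C[C@H](NC(=O)c1ccccc1)c1ccc(NC(=O)[C@H]2C[C@@H]2c2cccnc2)cc1` carries phenyl in place of ethyl on a carbonyl carbon. In this assay compound 2 reaches only a limit of the assay, < 4000 nM. The resulting step is an at least 13-fold lower number from compound 1 to compound 2 (1.13 log units; beyond the scatter), its size being set by the limit of < 4000 nM in this assay, at which 1 of the 2 values shown sits.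

Compound 3 `C[C@H](NC(=O)c1ccccn1)c1ccc(NC(=O)[C@H]2C[C@@H]2c2cccnc2)cc1` differs from compound 1 by pyridin-2-yl in place of ethyl on a carbonyl carbon. For the measured compounds named here, the one measured step that bears on this change, an at least 13-fold lower number from compound 1 to compound 2 (1.13 log units; beyond the scatter), was large and downward, and compound 3 likewise brings one six-membered aromatic ring onto that carbonyl carbon, so a drop of similar size is expected. The step of an 11-fold lower number from compound 1 to compound 3 (1.03 log units; beyond the scatter) is the estimate. Compound 3 is expected to give 5000 nM, within 1500 nM to 20000 nM, and the reading may again end at a limit rather than a number.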

Compound 3, solubility: 10000 nM
Estimate against measurement, compound 3: 2.0-fold (0.30 log units) below; the measured number falls inside the stated range.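

With compound 3, a six-membered aromatic ring on this carbonyl carbon has a full number in this assay, so the change from ethyl can now be sized rather than only bounded: the step is a 5.4-fold lower number from compound 1 to compound 3 (0.73 log units; beyond the scatter). The two aromatic rings also separate at this place, the step with pyridin-2-yl in place of phenyl being an at least 2.5-fold higher number from compound 2 to compound 3 (0.39 log units; beyond the scatter). That second step is only a bound, its size being set by a limit: the limit of < 4000 nM in this assay, at which 1 of the 3 values shown sits.

The compounds shown leave open whether pyridin-3-yl or pyridin-4-yl on this carbonyl carbon would read like pyridin-2-yl. They also leave open how a morpholine ring, an amine-bearing chain or a longer chain such as butyl would compare with ethyl at this place.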